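Diaryl ether series: cytotoxicity notes, compound 4 estimate

The source may report more compounds than this note shows. Statements on the series, on what has been measured and on what is new or still open speak of the compounds shown alone.

Measured so far:
compound 1 `Fc1ccc(Nc2cc(Nc3ccc(Oc4ccncc4-c4cccnc4)c(F)c3)ncn2)cc1F` — 7630 nM
compound 2 `Fc1cc(Nc2cc(Nc3ccc(Cl)cc3)ncn2)ccc1Oc1ccncc1-c1cccnc1` — 1610 nM
compound 3 `Cn1c(=O)c(C(=O)Nc2ccc(Oc3ccncc3-c3cccnc3)c(F)c2)nn(-c2ccccc2F)c1=O` — 610 nM

In a functional assay on A549 cells (Homo sapiens) for cytotoxicity, read by MTT assay, with a stated time of 72 h (on this read-out lower numbers stand for stronger inhibition and higher numbers for weaker inhibition), compound 3 gives the lowest number of the three; compound 2 sits above it and compound 1 furthest away. Compound 4 `Cn1c(=O)c(C(=O)Nc2ccc(Oc3ccncc3-c3cccnc3)c(F)c2)nn(-c2c(Cl)cccc2Cl)c1=O` keeps the core of compound 3 and changes only the aryl on the aromatic nitrogen: 2,6-dichlorophenyl in place of 2-fluorophenyl on an aromatic nitrogen. For the measured compounds named here, no measured step shares this core. Going by the values given here, the only single-point step recorded, a 4.7-fold lower number from compound 1 to compound 2 (0.68 log units; beyond the scatter), concerns an aryl on a nitrogen of a different core, so it is a weak guide; it shows that swapping halogens on such an aryl can move this assay by a modest amount in either direction. No strong shift is therefore expected for compound 4, and the estimate for compound 4 in this assay is 500 nM, within 150 nM to 2000 nM, corresponding to an expected step of a 1.2-fold lower number from compound 3 to compound 4 (0.09 log units; within the scatter).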

Compound 4, half-maximal inhibitory concentration: 720 nM
Compound 4: the middle estimate sits 1.4-fold (0.16 log units) below what was measured, within the range that was stated.
By their numbers in this assay, from the lowest: compounds 3 and 4 (each within the scatter of the next); then compound 2; then compound 1.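

In this assay, for the compounds shown here, 2,6-dichlorophenyl in place of 2-fluorophenyl on the aromatic nitrogen gives a 1.2-fold higher number from compound 3 to compound 4 (0.07 log units; within the scatter) and is the first step read on the core of compound 3. At this position, two chlorine atoms can replace one fluorine with no change beyond the scatter. No measured property bears on this result.

As far as these compounds go, whether an aryl group with an amine or a carboxylic acid, or a non-aryl group such as a longer alkyl chain, would give the same result on this nitrogen remains open.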